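Removing the fluoro group from compound 2

A few compounds are considered here, and "the series" means these few. Any claim that something is new, unique, unknown or untested is made for them only; others in the source may bear on it.

In a functional assay on HCT-116 cells (Homo sapiens) for antiproliferative activity, read by MTT assay, with a stated time of 48 h (on this read-out lower numbers stand for stronger inhibition and higher numbers for weaker inhibition), compound 1 `CCCC(CCO)n1cnc2c(Cl)ncnc21` gives > 50000 nM, which is a limit of the assay and not a number. Among the compounds with values here, compound 2 `CCCCCC(CCO)n1cnc2c(Cl)nc(F)nc21` gives 8660 nM, the only actual number so far. Compound 3 `CCCCCC(CCO)n1cnc2c(Cl)ncnc21` follows from compound 2 by one change: hydrogen in place of fluoro on an aromatic carbon. Within the data shown here, no measured step yet shows what this change does in this assay. A modest weakening is expected, and a 1.8-fold higher number from compound 2 to compound 3 (0.27 log units; within the scatter) is the estimated step. Compound 3 is estimated at 16000 nM, with an expected range of 6000 nM to 50000 nM.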

Compound 3, half-maximal inhibitory concentration: > 50000 nM
Compound 3: no number, only a limit (the forecaster's own chance of this, stated with the estimate: 15%); middle value at least 3.1-fold (0.49 log units) from the limit.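

The fluoro group between two ring nitrogen atoms now has a readable step: in this assay, hydrogen in its place gives an at least 5.7-fold higher number from compound 2 to compound 3 (0.76 log units; beyond the scatter). Within the data shown here, this is the first measured step at this position, and it shows that the longer chain shared by compound 2 and compound 3 does not by itself yield a number.

An amine or a methoxy group at this position remains untested within the compounds shown. The ethyl step from compound 1 to compound 3 cannot be read, because both values are limits: the limit of > 50000 nM in this assay, at which 2 of the 3 values shown sit.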